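The source may report more compounds than this note shows. Statements on the series, on what has been measured and on what is new or still open speak of the compounds shown alone.

Measured in an ADME assay on L02 cells (Homo sapiens) for cytotoxicity, read by MTT assay, with a stated time of 24 h; on this read-out higher numbers stand for weaker inhibition and lower numbers for stronger inhibition:
- compound 1 `O=C1/C(=C/c2ccncc2)CN(S(=O)(=O)c2ccc(Br)cc2)C/C1=C\c1ccccc1F` gives 19400 nM
- compound 2 `O=C1/C(=C/c2ccncc2)CN(S(=O)(=O)c2ccc(Cl)cc2)C/C1=C\c1ccccc1C(F)(F)F` gives 14900 nM

The value of compound 2 lies within the usual scatter of the value of compound 1, so these two numbers cannot be told apart. The two compounds also differ in more than one place, so their values cannot be tied to any single change.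

The next compound, not yet measured, is compound 3 `O=C1/C(=C/c2ccncc2)CN(S(=O)(=O)c2ccc(Br)cc2)C/C1=C\c1ccccc1C(F)(F)F`. It has bromo in place of chloro on an aromatic carbon of compound 2, para to a large group, turning 4-chlorophenyl into 4-bromophenyl (bromo in place of chloro on an aromatic carbon). Among the compounds with values here, no measured pair shows this swap alone. The closest evidence is that compound 1, which also carries 4-bromophenyl, gives (19400 nM), within the scatter of compound 2 (14900 nM). No step beyond the scatter is therefore expected in this assay, in either direction.

The expected change (a 1.0-fold higher number from compound 2 to compound 3 (0.02 log units; within the scatter)) is small. The estimated value for compound 3 is 15500 nM, with an expected range from 8500 nM to 28000 nM.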

Compound 3, half-maximal inhibitory concentration: 12600 nM
Compound 3: middle estimate off by 1.2-fold (0.09 log units), on the high side, within the range that was stated.
By their numbers in this assay, from the lowest: compounds 3, 2 and 1 (each within the scatter of the next).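

In this assay, within the data shown here, turning 4-chlorophenyl into 4-bromophenyl gives a 1.2-fold lower number from compound 2 to compound 3 (0.07 log units; within the scatter), which is the first reading of this swap on its own, with nothing else in the molecule altered. The second single change, trifluoromethyl in place of fluoro on an aromatic carbon of the other substituted ring, gives a 1.5-fold lower number from compound 1 to compound 3 (0.19 log units; within the scatter), so that place can now also be read by itself. Neither step rises above the ordinary spread of repeated measurements, so chloro and bromo cannot be told apart at the first place, nor fluoro and trifluoromethyl at the second, and no measurement here offers an explanation for these readings.

The compounds shown leave open whether a group of a different kind on the sulfonyl-bearing ring, such as an amine or a carboxylic acid in place of the bromo, would produce a step beyond that spread. From the compounds shown here alone, it is equally open whether a methoxy group or a longer alkyl chain in place of the trifluoromethyl would do so.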